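A few compounds are considered here, and "the series" means these few. Any claim that something is new, unique, unknown or untested is made for them only; others in the source may bear on it.

Working notes on the series

Of the compounds shown here, three have been measured in a functional assay on NCI-H23 cells (Homo sapiens) for cytotoxicity, read by sulforhodamine B assay, with a stated time of 48 h; a higher number here means a weaker inhibitor of growth, a lower number a stronger inhibitor of growth. Compound 1, `ClCc1ccccc1Cn1cnc2c(Cl)nc(Cl)nc21`, gives 3090 nM. Compound 2, `ClCc1ccccc1Cn1cnc2c(Cl)ncnc21`, gives 4360 nM. Compound 3, `ClCc1ccc(Cn2cnc3nc(Cl)nc(Cl)c32)cc1`, gives 4570 nM. All three numbers sit within the scatter of one another, so no order among them is claimed.

Compound 1 and compound 2 differ in one place: hydrogen in place of chloro on an aromatic carbon. The measured step is a 1.4-fold higher number from compound 1 to compound 2 (0.15 log units; within the scatter), which is within the scatter.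

Compound 3 carries the same atoms as compound 1 joined differently; the difference between the two cores is not broken down here. What the two values show is that compound 3 and compound 1 lie within the scatter of each other.

Compound 4, `ClCc1ccc(Cn2cnc3ncnc(Cl)c32)cc1`, is not yet measured. It stands to compound 3 as compound 2 stands to compound 1: hydrogen in place of chloro on an aromatic carbon. The place described is the same, word for word, as for the earlier change, so this is the same change made on the other core.

The step expected here is a 1.4-fold higher number from compound 3 to compound 4 (0.14 log units; within the scatter), and this rests on the measured step of a 1.4-fold higher number from compound 1 to compound 2 (0.15 log units; within the scatter) being within the scatter. The only support for the expectation is that single pair; no other repeat of the change exists among the compounds measured. For compound 4 the estimate in this assay is 6300 nM, with a range from 3200 nM to 12500 nM.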

Compound 4, concentration for total growth inhibition: 30900 nM
The estimate for compound 4 lay 4.9-fold (0.69 log units) below the measured number; measured number above the stated range.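

In this assay, hydrogen in place of chloro on the aromatic carbon between two ring nitrogen atoms gives a 6.8-fold higher number from compound 3 to compound 4 (0.83 log units; beyond the scatter), so the change does not carry over at the same size from one core to the other: the same change on two cores in this assay, a 1.4-fold higher number (0.15 log units; within the scatter) from compound 1 to compound 2 and a 6.8-fold higher number (0.83 log units; beyond the scatter) from compound 3 to compound 4, 4.8-fold (0.68 log units) apart, beyond the scatter of two such steps On the core of compound 1 the step stays within the scatter, while on the core of compound 3 it goes beyond it, so the step measured on one core was no safe guide to the step on the other in this pair of cores. This does not show why the two steps differ, and with a single pair on each core it gives no rule for any further core or any further change in the series.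

As far as these compounds go, it remains open whether an amine or a methoxy group on that same aromatic carbon would give numbers closer to the chloro compounds or to the hydrogen compounds on either core. From the compounds shown here alone, it is also open whether the gap of the two steps holds on other cell lines, since everything here rests on one assay, and whether it survives repeated measurement of compound 4.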